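A few compounds are considered here, and "the series" means these few. Any claim that something is new, unique, unknown or untested is made for them only; others in the source may bear on it.

Of the compounds shown here, three built on one shared core have been measured in a functional assay on MCF7 cells (Homo sapiens) for inhibition, read by sulforhodamine B assay; on this read-out lower numbers stand for stronger inhibition and higher numbers for weaker inhibition. Compound 1 `O=C1C(Nc2ccccc2F)=CC(=O)c2c1nc1n2[C@H]2OC[C@@H](O)[C@H]2OC1` carries a (2-fluorophenyl)amino group. In this assay compound 1 reaches only the assay limit > 4000 nM, not a number. Compound 2 `O=C1C=C(N2CCC2)C(=O)c2c1nc1n2[C@H]2OC[C@@H](O)[C@H]2OC1` carries azetidin-1-yl, a small cyclic amine, and compound 2 also gives only the limit > 16000 nM. Compound 3 `O=C1C=C(Nc2ccc(Br)cc2)C(=O)c2c1nc1n2[C@H]2OC[C@@H](O)[C@H]2OC1` carries (4-bromophenyl)amino, and compound 3 gives 2580 nM. Swapping the cyclic amine for an arylamine thus gave the step of an at least 6.2-fold lower number from compound 2 to compound 3 (0.79 log units; beyond the scatter). Compound 4 `O=C1C(NC2CC2)=CC(=O)c2c1nc1n2[C@H]2OC[C@@H](O)[C@H]2OC1` differs from compound 1 by cyclopropyl in place of 2-fluorophenyl on an amine nitrogen, moving the opposite way, from an arylamine to a small alkylamine. Since compound 1 already sits at a limit, compound 4 is expected to be weak, around 12000 nM, between 3000 nM and 50000 nM, most probably reported again only as a limit. The expected step is then a step that the limit leaves unreadable from compound 1 to compound 4.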

Compound 4, half-maximal inhibitory concentration: > 16000 nM
Compound 4 ended at the assay's limit (the forecaster's own chance of this, stated with the estimate: 70%); middle value at least 1.3-fold (0.12 log units) away from the limit.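

Going by these compounds alone, compound 1 and compound 4 both stop at limits in this assay, not at numbers, so no step between them can be read. The compounds shown leave open whether (2-fluorophenyl)amino or cyclopropylamino gives stronger inhibition.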